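Dropping the Isobutyl Branch from Compound 2

This account rests on a few compounds, and the source may have more. Where it says the series, first, only, none or still open, it means among the compounds named here.

Compound 2 `CCCCCCCCCN(CC(C)C)c1ccc(OC)cc1` was examined in a functional assay on L929 cells (Mus musculus) for inhibition, read by MTT assay, with a stated time of 5 days (on this read-out lower numbers stand for stronger inhibition and higher numbers for weaker inhibition), where compound 2 gives 20 ug/mL. Of the two numbers recorded so far this is the highest, yet its nearest neighbour, compound 1 `COc1ccc(N(Cc2ccccc2OC)CC(C)C)cc1`, which in this assay gives 15 ug/mL, sits so close that the gap lies within the scatter of repeated measurements, and the two cannot be told apart. Compound 3 `CCCCCCCCCNc1ccc(OC)cc1` remains to be measured. It differs from compound 2 in a single place: hydrogen in place of isobutyl on a nitrogen on an aromatic ring. Within the data shown here, no step between measured compounds mirrors this change, so nothing recorded reveals its size or direction. With only the two neighbouring numbers to lean on, the expected step is a 1.3-fold higher number from compound 2 to compound 3 (0.10 log units; within the scatter), small and likely to stay within the usual scatter. Compound 3 is therefore estimated at 25 ug/mL, with a range from 8 ug/mL to 70 ug/mL.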

Compound 3, half-maximal inhibitory concentration: 12 ug/mL
The estimate for compound 3 lay 2.1-fold (0.32 log units) above the measured number; the measured number falls inside the stated range.
By their numbers in this assay, from the lowest: compounds 3, 1 and 2 (each within the scatter of the next).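

In this assay, hydrogen in place of isobutyl on a nitrogen on an aromatic ring gives a 1.7-fold lower number from compound 2 to compound 3 (0.22 log units; within the scatter) and so leaves compound 2 and compound 3 indistinguishable. Among these compounds, compound 1 and compound 2 both carry the isobutyl, so only this step shows that the branch can leave this nitrogen without a change that stands clear of the scatter, at least while the saturated chain stays in place. Nothing available explains this result or bears on how the nitrogen's surroundings contribute to it.

As far as these compounds go, whether a longer chain, a carboxylic acid or an amine on this nitrogen would also leave the number within the scatter remains open. From the compounds shown here alone, it is equally open whether the same exchange on the core of compound 1 would give a step of similar size.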